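The source may hold more compounds than are shown below. What is called first, only, known or untested is meant among the compounds shown, and "the series" means these compounds.

Compound 1 `Nc1nc(N)nc(-c2cc(F)ccc2Cl)n1`: 78% in a functional assay on the whole organism with Rattus norvegicus as the target, at a dose of 20 mg/kg by the intraperitoneal route; on this read-out lower numbers stand for less inhibition and higher numbers for more inhibition at the one dose given (going by the name of the read-out)
Compound 2 `Nc1nc(N)nc(-c2cccc(C(F)(F)F)c2)n1`: 81%
Compound 3 `Nc1nc(N)nc(-c2cc(Br)ccc2Cl)n1`: 86%

Compound 3 gives the number that happens to stand highest of the three, but its gap to compound 2 and its gap to compound 1 are both within the usual scatter, so the three measured compounds cannot be told apart on these numbers.

Compound 4 `Nc1nc(N)nc(-c2cc(C(F)(F)F)ccc2Cl)n1` is not yet measured. It differs from compound 3 in one place: trifluoromethyl in place of bromo on an aromatic carbon.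

Going by the values given here, only one measured step touches a change at this aromatic carbon: a number 8 percentage points higher from compound 1 to compound 3 (within the scatter). It concerns a different swap and was itself within the scatter. Compound 2 already carries a trifluoromethyl group, though without the chloro group, and its number sits close to that of compound 3. Nothing measured here points to a step beyond the scatter for a trifluoromethyl group entering in place of bromo.

The expected step is therefore a number 2 percentage points lower from compound 3 to compound 4 (within the scatter), that is, none beyond the scatter. Compound 4 is estimated at 84%, with a range from 72% to 94%.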

Compound 4, a percentage reported as inhibition, in the whole organism at one dose (the size of the read-out at that dose, not a potency): 51%
Compound 4: the middle estimate sits 33 percentage points above what was measured; the measured number lies below the stated range.
By their numbers in this assay, from the lowest: compound 4; then compounds 1, 2 and 3 (each within the scatter of the next).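

In this assay, this aromatic carbon, para to a chloro group, proves sensitive to which group it carries: trifluoromethyl in place of bromo gives a number 35 percentage points lower from compound 3 to compound 4 (beyond the scatter), and trifluoromethyl in place of fluoro gives a number 27 percentage points lower from compound 1 to compound 4 (beyond the scatter), whereas bromo in place of fluoro gave only a number 8 percentage points higher from compound 1 to compound 3 (within the scatter). The trifluoromethyl group does not go with a low number on its own, since chloro in place of hydrogen gives a number 30 percentage points lower from compound 2 to compound 4 (beyond the scatter), so the fall appears in these compounds only when both groups are present. Nothing given here explains the fall.

Still open, going by these compounds, is whether a methyl group, a methoxy group or a nitrile on this carbon would stay with bromo and fluoro or fall with trifluoromethyl. On these data alone, with a single dose, how this gap would look at other doses also remains open.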